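This account rests on a few compounds, and the source may have more. Where it says the series, first, only, none or still open, it means among the compounds named here.

Of the compounds shown here, three built on one shared core have been tested in an assay on isolated protein for inhibition of alpha-ketoglutarate-dependent dioxygenase alkB homolog 3 (Homo sapiens), read by polymerase chain reaction, with a stated time of 1 h; a lower number here means a stronger inhibitor, a higher number a weaker inhibitor. Compound 1 `Cc1[nH]n(-c2nc3ccccc3[nH]2)c(=O)c1Cc1ccccc1Cl` returns only a limit in this assay, > 10000 nM; it is the compound sitting at the limit of > 10000 nM in this assay, at which 1 of the 3 values shown sits. Compound 2 `Cc1ccc2[nH]c(-n3[nH]c(C)c(Cc4ccc(-c5ccccc5)cc4)c3=O)nc2c1` gives 5300 nM in this assay, while compound 3 `Cc1ccc2[nH]c(-n3[nH]c(C)c(Cc4ccc(Cl)c(Cl)c4)c3=O)nc2c1` gives 720 nM. Compound 4 `COC(=O)Cc1c(C)[nH]n(-c2nc3ccccc3[nH]2)c1=O` awaits measurement. It differs from compound 1 by methoxycarbonyl in place of 2-chlorophenyl on a saturated chain carbon bound to an aromatic carbon. Among the compounds with values here, no measured pair carries this change, so its size is unknown, and with compound 1 known only as a limit the step cannot be pinned down. The step is estimated as a step that the limit leaves unreadable from compound 1 to compound 4, meaning no movement beyond the scatter is expected. Compound 4 is therefore expected to give about 20000 nM in this assay, somewhere between 5000 nM and 100000 nM, and quite possibly again only as a limit.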

Compound 4, half-maximal inhibitory concentration: 4300 nM
For compound 4 the middle estimate is 4.7-fold (0.67 log units) above the measured one; the measured number lies below the stated range.
By their numbers in this assay, from the lowest: compound 3; then compounds 4 and 2 (each within the scatter of the next). At a limit, above all of these: compound 1.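

At this position, an aromatic ring is not required for a measurable number in this assay: methoxycarbonyl in place of 2-chlorophenyl on a saturated chain carbon bound to an aromatic carbon gives an at least 2.3-fold lower number from compound 1 to compound 4 (0.36 log units; beyond the scatter). The swap removes the ring and brings in two hydrogen-bond acceptors, and this one pair cannot separate those two differences. The step is only a minimum, as compound 1 is known only as a limit: the limit of > 10000 nM in this assay, at which 1 of the 4 values shown sits.

The compounds shown leave open whether a carboxylic acid or an amide in place of methoxycarbonyl would keep this number, and whether a longer chain would change it.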